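Losing the hydroxy group: from compound 2 to compound 3

The compounds below may be only part of what the source reports. "The series", "measured", "known", "first", "only" and "open" are said of these compounds alone.

Compound 2 `CN1CCN(c2nc3ccccc3n2CCOCCO)CC1` was measured in a functional assay on ileum for inhibition of histamine H1 receptor (Cavia porcellus) (on this read-out lower numbers stand for stronger inhibition and higher numbers for weaker inhibition), where compound 2 gives 42 nM. Among the two numbers seen so far this is the higher one; the only neighbour is compound 1 `C#CCOCCn1c(N2CCN(C)CC2)nc2ccccc21`, which in this assay gives 12 nM. Among the measured compounds shown here, the one step that joins them, a 3.5-fold higher number from compound 1 to compound 2 (0.54 log units; beyond the scatter), swapped an ethynyl for a hydroxymethyl on a saturated chain carbon bound to an oxygen on a saturated carbon.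

Compound 3 `CCCCOCCn1c(N2CCN(C)CC2)nc2ccccc21` is not yet measured. It differs from compound 2 by ethyl in place of hydroxy on a saturated chain carbon, two bonds along the chain from an oxygen on a saturated carbon; read one bond further out, the 2-hydroxyethoxy side chain of compound 2 becomes a butoxy chain. This removes the hydroxy that entered with the step from compound 1 to compound 2 and leaves a plain chain, roughly comparable to the side chain of compound 1. For the measured compounds named here, no measured step follows exactly this exchange, so the step from compound 1 to compound 2 is the only guide. On that basis compound 3 is expected to move back toward compound 1, by about a 2.8-fold lower number from compound 2 to compound 3 (0.45 log units; beyond the scatter) in this assay. The estimate for compound 3 is therefore 15 nM, with a range from 5 nM to 50 nM.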

Compound 3, half-maximal inhibitory concentration: 38 nM
For compound 3 the middle estimate is 2.5-fold (0.40 log units) below the measured one; low and high end bracket the measured number.
By their numbers in this assay, from the lowest: compound 1; then compounds 3 and 2 (each within the scatter of the next).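

Swapping the hydroxy for ethyl, which turns the 2-hydroxyethoxy side chain into butoxy, gives a 1.1-fold lower number from compound 2 to compound 3 (0.04 log units; within the scatter) in this assay, so this position tolerates the loss of the hydrogen-bond donor and acceptor without a measurable change on this read-out. The plain chain does not match the ethynyl-ended chain, with a 3.2-fold higher number from compound 1 to compound 3 (0.50 log units; beyond the scatter) and a difference that lies beyond the usual scatter, so the hydroxy alone cannot account for the gap first seen between the ethynyl and hydroxymethyl compounds: replacing it with plain carbon does not close that gap. Nothing available here explains why the ethynyl end stands apart from these two chain ends.

A carboxylic acid or an amine at the end of the chain, or a longer chain such as hexyloxy, would help show whether the ethynyl end is a special case or whether other chain ends can also reach the level of compound 1. As far as these compounds go, it also remains open how far these small differences carry over to any setting other than this single ileum read-out.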